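The source may hold more compounds than are shown below. What is called first, only, known or untested is meant among the compounds shown, and "the series" means these compounds.

Compound 1 `N#Cc1c[nH]c2c(NS(=O)(=O)c3ccc(C(N)=O)cc3)cccc12`: 15 ug/mL
Compound 2 `COc1ccc(S(=O)(=O)Nc2cccc3c(Cl)c[nH]c23)cc1`: 0.55 ug/mL

Both compounds were tested in a functional assay on KB cells (nasopharynx, Homo sapiens) for antiproliferative activity; on this read-out lower numbers stand for stronger inhibition and higher numbers for weaker inhibition. Compound 2 gives 0.55 ug/mL, the lower of the two numbers. Compound 1 gives 15 ug/mL. The gap between these two compounds lies beyond the scatter. Compound 3 `NC(=O)c1ccc(S(=O)(=O)Nc2cccc3c(Cl)c[nH]c23)cc1` has carbamoyl in place of methoxy on an aromatic carbon, para to a large group: carbamoyl in place of methoxy on an aromatic carbon. For the measured compounds named here, no measured pair isolates this change, so its size in this assay can only be expected. Going by the values given here, the one measured compound bearing carbamoyl is compound 1 at 15 ug/mL, but it differs from compound 2 in more than one place. A move towards a higher number, meaning weaker inhibition, is therefore expected, probably beyond the scatter but short of the full gap between those two compounds. The estimated move is a 4.5-fold higher number from compound 2 to compound 3 (0.66 log units; beyond the scatter). For compound 3 the expected value is 2.5 ug/mL, with an estimated range of 0.6 ug/mL to 10 ug/mL.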

Compound 3, half-maximal inhibitory concentration: 21 ug/mL
Compound 3: middle estimate off by 8.4-fold (0.92 log units), on the low side, and the stated range ends below it.
By their numbers in this assay, from the lowest: compound 2; then compounds 1 and 3 (each within the scatter of the next).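

In this assay, for the compounds shown here, carbamoyl in place of methoxy on an aromatic carbon, para to a large group, gives a 38-fold higher number from compound 2 to compound 3 (1.58 log units; beyond the scatter), the first measured pair to isolate this change, and the step is large. With carbamoyl held constant, chloro in place of cyano on an aromatic carbon gives a 1.4-fold higher number from compound 1 to compound 3 (0.15 log units; within the scatter), so that swap makes no readable difference in this setting. Nothing measured here gives a reason for the large step at the methoxy position.

As far as these compounds go, it remains open whether other groups at this position, such as a carboxylic acid, an amine or a methyl, would stay close to compound 2 or fall towards compound 3. Also open, from the compounds shown here alone, is whether chloro and cyano would remain indistinguishable with methoxy in place of carbamoyl.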